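Swapping a Saturated Ring for an Aromatic One

The source may report more compounds than this note shows. Statements on the series, on what has been measured and on what is new or still open speak of the compounds shown alone.

Of the compounds shown here, two have been measured in a functional assay for inhibition of Polyunsaturated fatty acid 5-lipoxygenase (Homo sapiens); a higher number here means a weaker inhibitor, a lower number a stronger inhibitor. Compound 1 `C/C(=N\OC(c1ccc(OCc2ccc3ccccc3n2)cc1)C1CCCC1)C(=O)O` gives 16 nM. Compound 2 `C/C(=N\OC(CC1CCCCC1)c1ccc(OCc2ccc3ccccc3n2)cc1)C(=O)O` gives 29 nM. The step of a 1.8-fold higher number from compound 1 to compound 2 (0.26 log units; within the scatter) lies within the scatter, so compound 2 and compound 1 cannot be told apart on these numbers, and compound 2 stands nowhere in particular relative to compound 1.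

Compound 3 `C/C(=N\OC(Cc1ccccc1)c1ccc(OCc2ccc3ccccc3n2)cc1)C(=O)O` differs from compound 2 by phenyl in place of cyclohexyl on a saturated chain carbon, two bonds along the chain from an aromatic carbon and an oxygen. Among the measured compounds shown here, only one measured step touches this part of the chain, a 1.8-fold higher number from compound 1 to compound 2 (0.26 log units; within the scatter), and it exchanged one saturated ring for another of different size without moving the number beyond the scatter. The change to compound 3 exchanges a saturated ring for an aromatic one of the same size, a change of a different kind, so that single step gives only weak guidance. A step of a 1.2-fold higher number from compound 2 to compound 3 (0.08 log units; within the scatter) is expected, which is to say nothing beyond the scatter. Compound 3 is therefore estimated at 35 nM in this assay, with a range from 12 nM to 100 nM.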

Compound 3, half-maximal inhibitory concentration: 30 nM
Compound 3: middle estimate off by 1.2-fold (0.07 log units), on the high side, within the range that was stated.
By their numbers in this assay, from the lowest: compounds 1, 2 and 3 (each within the scatter of the next).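

In this assay, exchanging a saturated ring for an aromatic one of the same size at this place gives a 1.0-fold higher number from compound 2 to compound 3 (0.01 log units; within the scatter), so cyclohexyl and phenyl cannot be told apart here. The earlier step only exchanged one saturated ring for another, whereas this result shows that an aromatic ring also leaves the number within the scatter, and the wider exchange of cyclopentyl for benzyl, a 1.9-fold higher number from compound 1 to compound 3 (0.27 log units; within the scatter), stays within it too. Nothing at hand explains why these rings read alike.

As far as these compounds go, all three compounds carry a ring of carbon only at this place, so it remains open whether a pyridyl ring, which holds a nitrogen, would read the same. Also open, from the compounds shown here alone, is how a phenyl ring bearing an amine or a carboxylic acid would compare, or a plain ethyl chain with no ring.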